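This account rests on a few compounds, and the source may have more. Where it says the series, first, only, none or still open, it means among the compounds named here.

Measured compounds in a functional assay on the whole organism (Tail, strain ICR) with Mus musculus as the target, in the tail flick test, with a stated time of 120 min, at a dose of 25 umol/kg by the oral route; a higher number here means a stronger effect of the compound at the dose given, a lower number a weaker effect:

- compound 1 `NC(=O)CC[C@H](NC(=O)CN(c1ncnc2c1ncn2C1CCCCO1)C1CC1)C(=O)OCc1ccccc1`: 22.3%
- compound 2 `CC[C@H](C)[C@H](NC(=O)CN(c1ncnc2c1ncn2C1CCCCO1)C1CC1)C(=O)OCc1ccccc1`: 20.4%
- compound 3 `O=C(CN(c1ncnc2c1ncn2C1CCCCO1)C1CC1)N[C@@H](CO)C(=O)OCc1ccccc1`: 29.2%

Compound 3 holds the highest of the three numbers, but the steps leading to it, a number 6.9 percentage points higher from compound 1 to compound 3 (within the scatter) and a number 8.8 percentage points higher from compound 2 to compound 3 (within the scatter), both fall within the scatter, so no ranking among the three is supported.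

Compound 4 `NC(=O)C[C@H](NC(=O)CN(c1ncnc2c1ncn2C1CCCCO1)C1CC1)C(=O)OCc1ccccc1` differs from compound 3 by carbamoyl in place of hydroxy on a saturated chain carbon, two bonds along the chain from an amide-type nitrogen and a carbonyl carbon. For the measured compounds named here, the step that bears most directly on this change is the one from compound 1 to compound 3, a number 6.9 percentage points higher from compound 1 to compound 3 (within the scatter): there a carbamoyl-bearing chain (2-carbamoylethyl) was exchanged for hydroxy, and the number moved only within the scatter. Compound 4 reverses that kind of exchange, though with carbamoylmethyl rather than 2-carbamoylethyl. The step from compound 2 to compound 3, a number 8.8 percentage points higher from compound 2 to compound 3 (within the scatter), also within the scatter, adds nothing pointing the other way. On this basis no step beyond the scatter is expected in this assay, at most a small drift downward, a number 5.2 percentage points lower from compound 3 to compound 4 (within the scatter). Compound 4 is therefore estimated at 24%, with a range of 13% to 35%.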

Compound 4, a percentage reported as activity, at one dose (the size of the read-out at that dose, not a potency): 29.2%
Compound 4: middle estimate off by 5.2 percentage points, on the low side, and the stated range covers the measured number.
By their numbers in this assay, from the lowest: compounds 2, 1, 3 and 4 (each within the scatter of the next).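

Carbamoyl and hydroxy at the saturated chain carbon, two bonds along the chain from an amide-type nitrogen and a carbonyl carbon, cannot be told apart in this assay, with no change at the digits printed from compound 3 to compound 4 (within the scatter) for the exchange. Against the other side chains the picture is equally flat, with a number 8.8 percentage points higher from compound 2 to compound 4 (within the scatter) for carbamoylmethyl in place of sec-butyl and a number 6.9 percentage points higher from compound 1 to compound 4 (within the scatter) for carbamoyl in place of carbamoylmethyl, so the series now offers no step at this position that stands clear of the scatter. Nothing available bears on why the read-out stays this flat.

From the compounds shown here alone, whether a carboxylic acid, an amine or a longer chain carrying a terminal amine at this carbon would move the read-out beyond the scatter remains open. With a single dose and time point, the compounds shown also leave open whether any differences would appear at other doses or times.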